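The source may hold more compounds than are shown below. What is called first, only, known or untested is meant among the compounds shown, and "the series" means these compounds.

Compound 1 `COc1ccc(-c2nc3c(NC4CCCC4)ncnc3n2C)cc1` has the lowest number of the three compounds measured in an assay on CHO cells for displacement of a labelled ligand from adenosine receptor A3 (Homo sapiens), read by scintillation counting, with a stated time of 3 h (on this read-out higher numbers stand for weaker inhibition and lower numbers for stronger inhibition), where compound 1 gives 1850 nM. Compound 2 `Cn1c(-c2ccccc2)nc2c(NC3CCCCC3)ncnc21` gives 2370 nM, a gap from compound 1 that lies within the scatter. Compound 3 `Cn1c(-c2ccc(C(=O)O)cc2)nc2c(NC3CCCC3)ncnc21` gives 25700 nM, and the step of a 14-fold higher number from compound 1 to compound 3 (1.14 log units; beyond the scatter) is large for a single change on the phenyl ring. Compound 4 `Cn1c(-c2ccccc2Cl)nc2c(NC3CCCC3)ncnc21` is not yet measured; it differs from compound 1 by 2-chlorophenyl in place of 4-methoxyphenyl on an aromatic carbon. Within the data shown here, only the step from compound 1 to compound 3 concerns the same ring, and it shows that a change there can move the number far. Compound 2 carries an unsubstituted phenyl and its number lies close to that of compound 1, so only a modest shift is expected here. The estimated step of a 1.4-fold higher number from compound 1 to compound 4 (0.13 log units; within the scatter) is expected to stay near the scatter. For compound 4 the expected value is 2500 nM, with a range from 800 nM to 8000 nM.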

Compound 4, inhibition constant: 720 nM
Compound 4: the middle estimate sits 3.5-fold (0.54 log units) above what was measured; measured number outside the range, below it.
By their numbers in this assay, from the lowest: compound 4; then compounds 1 and 2 (each within the scatter of the next); then compound 3.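

In this assay, the step of a 2.6-fold lower number from compound 1 to compound 4 (0.41 log units; beyond the scatter) shows that a change on this phenyl ring can also lower the number, whereas the earlier change to carboxy in compound 3 raised it. This swap removes the methoxy group and puts chlorine at a different place on the ring, so two things change at once. Nothing measured here explains the shift.

From the compounds shown here alone, whether the chlorine itself or its place on the ring drives the step stays open. So does what an amine or a fluorine at that same place would give.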